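Adding a Methyl to Compound 2: Expected Cytotoxicity

A few compounds are considered here, and "the series" means these few. Any claim that something is new, unique, unknown or untested is made for them only; others in the source may bear on it.

Of the compounds shown here, two have so far been tested in a functional assay on C3H/3T3 cells (Mus musculus) for cytotoxicity; on this read-out higher numbers stand for lower toxicity in this test and lower numbers for higher toxicity in this test. Compound 1 `COc1ccc2c(c1)COP(=O)(OC[C@@H]1C=C[C@H](n3cnc4c(N)ncnc43)O1)O2` reaches only the assay limit, giving > 50000 nM; > 50000 nM; > 50000 nM (3 entries) in this assay. Compound 2 `Nc1ncnc2c1ncn2[C@H]1C=C[C@@H](COP2(=O)OCc3ccccc3O2)O1` likewise gives only a limit, > 50000 nM in this assay, and no single number exists for it. The values shown include (the limit of > 50000 nM in this assay, at which 1 of the 2 values shown sits), so compound 2 stands at the edge of what this assay can report, with no detectable toxicity in the tested range. Compound 3 `Cc1cccc2c1OP(=O)(OC[C@@H]1C=C[C@H](n3cnc4c(N)ncnc43)O1)OC2` has not yet been measured; it differs from compound 2 by methyl in place of hydrogen on an aromatic carbon. Going by the values given here, no measured step between compounds is available, so the effect of this change cannot be read from the data. The step is expected to lie within the scatter, with a step that the limit leaves unreadable from compound 2 to compound 3 expected. Compound 3 is therefore estimated to give about 60000 nM, in a range from 30000 nM to 150000 nM, and most likely again only a limit.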

Compound 3, minimum cytotoxic concentration in the C3H/3T3 assay: > 50000 nM
Compound 3: no number, only a limit (the forecaster's own chance of this, stated with the estimate: 85%); the middle value lies beyond the limit too.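

Going by these compounds alone, in the C3H/3T3 assay compound 3 gives only a limit, as compound 2 does, so no step between compound 2 and compound 3 can be read: the limit of > 50000 nM in the C3H/3T3 assay, at which 2 of the 3 values shown sit. In a physicochemical assay for lipophilicity (a lower number here means a more polar compound, a higher number a more lipophilic compound), compound 2 gives 0.36 and compound 3 gives 0.63, which is a number 0.27 log units higher from compound 2 to compound 3 (within the scatter). The compounds shown leave open what toxicity any of them would show in the C3H/3T3 assay beyond that limit.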